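Swapping the Piperazine Substituent Back to an Aryl Group

A few compounds are considered here, and "the series" means these few. Any claim that something is new, unique, unknown or untested is made for them only; others in the source may bear on it.

Compound 2 `Nc1scc(CN2CCN(CCCc3ccc(Cl)cc3)CC2)c1C(=O)c1ccc(Cl)cc1` was tested in an assay on CHO cells for displacement of a labelled ligand from adenosine receptor A3 (Homo sapiens), read by scintillation counting, with a stated time of 120 min, tested at 10 uM (on this read-out lower numbers stand for less inhibition and higher numbers for more inhibition at the one concentration tested (going by the name of the read-out)), and gives 0%. This puts compound 2 level with compound 1 `Nc1scc(CN2CCN(c3c(F)cc(F)cc3F)CC2)c1C(=O)c1ccc(Cl)cc1`, which in this assay gives 0%. Among the compounds with values here, the one measured step joining these two, no change at the digits printed from compound 1 to compound 2 (within the scatter), shows that exchanging the aryl group on the ring nitrogen for a chain carrying a chlorophenyl made no difference that rises above the usual scatter.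

Compound 3 `Nc1scc(CN2CCN(c3cc(Cl)ccc3Cl)CC2)c1C(=O)c1ccc(Cl)cc1` has not yet been measured. It differs from compound 2 in a single place: 2,5-dichlorophenyl in place of 3-(4-chlorophenyl)propyl on an amine nitrogen in a ring. The change returns an aryl group to the same ring nitrogen that carries an aryl group in compound 1, so the step that bears on it is no change at the digits printed from compound 1 to compound 2 (within the scatter), which was flat. Within the data shown here, compound 1 and compound 2 both sit at the bottom of the read-out, and nothing among the measured compounds points to a rise when the substituent on that nitrogen changes. The step from compound 2 to compound 3 is therefore expected to be no change at the digits printed from compound 2 to compound 3 (within the scatter), that is, no movement beyond the scatter. For compound 3 in this assay the expected value is 0%, with a range from -8% to 15%.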

Compound 3, a percentage reported as inhibition, at one concentration (the size of the read-out at that concentration, not a potency): 1%
The estimate for compound 3 lay 1 percentage points below the measured number, within the range that was stated.
By their numbers in this assay, from the lowest: compounds 1, 2 and 3 (each within the scatter of the next).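

In this assay, putting an aryl group straight onto the ring nitrogen in place of the chain gives a number 1 percentage points higher from compound 2 to compound 3 (within the scatter) and so does not bring the read-out off the floor. A second aryl pattern now stands at this place as well: 2,5-dichlorophenyl in place of 2,4,6-trifluorophenyl gives a number 1 percentage points higher from compound 1 to compound 3 (within the scatter) and shows that exchanging three fluorines for two chlorines on that ring makes no difference beyond the scatter, so two aryl groups and one chain on this nitrogen all read alike at the one concentration tested. No measurement at hand explains why these values stay so low.

Still open, as far as these compounds go, is whether a substituent of a different kind on this nitrogen, such as a chain ending in an amine or a carboxylic acid, would give any inhibition in this test. All three compounds also share the rest of their structure, which leaves open whether a change elsewhere in the core of compound 1 would move the read-out at all.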